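Swapping the pyrazole arm in an EZH2 inhibitor series

The source may report more compounds than this note shows. Statements on the series, on what has been measured and on what is new or still open speak of the compounds shown alone.

Compound 1, `CCn1cc(CNC(=O)[C@@H](N)CCSC[C@H]2O[C@@H](n3cnc4c(N)ncnc43)[C@H](O)[C@@H]2O)cn1` — in an assay on Sf9 cells for inhibition of histone-lysine N-methyltransferase EZH2 (Homo sapiens), read by scintillation counting, in the presence of a further agent that is not named here (a lower number here means a stronger inhibitor, a higher number a weaker inhibitor), compound 1 gives 50000 nM.
Compound 2, `Nc1ncnc2c1ncn2[C@@H]1O[C@H](CSCC[C@H](N)C(=O)NCc2cnn(-c3ccc(F)cc3)c2)[C@@H](O)[C@H]1O` — in this assay compound 2 gives 1400 nM.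

Among the compounds with values here, compound 2 stands lowest of the two numbers measured so far, with compound 1 the only neighbour for comparison. Within the data shown here, the one measured step, a 36-fold lower number from compound 1 to compound 2 (1.55 log units; beyond the scatter), shows that the aromatic substituent on the ring nitrogen matters a great deal.

Compound 3 is `COCc1cc(CNC(=O)[C@@H](N)CCSC[C@H]2O[C@@H](n3cnc4c(N)ncnc43)[C@H](O)[C@@H]2O)n[nH]1`. It differs from compound 2 by a group of 8 heavy atoms (5 carbon, 2 nitrogen, 1 oxygen; one five-membered aromatic ring with 2 hetero atoms) in place of a group of 12 heavy atoms (9 carbon, 2 nitrogen, 1 fluorine; one five-membered aromatic ring with 2 hetero atoms, one six-membered aromatic ring of carbon only), on a saturated chain carbon bound to an amide-type nitrogen. The change goes in the opposite direction from the measured step: the four-fluorophenyl that accompanied the large gain in compound 2 is removed, and a smaller group, with one hydrogen-bond donor, takes its place. Because a 36-fold lower number from compound 1 to compound 2 (1.55 log units; beyond the scatter) was large, stripping away that same group is expected to cost potency, though the replacement is not the ethyl of compound 1, so the outcome is uncertain. The expected step is an 11-fold higher number from compound 2 to compound 3 (1.03 log units; beyond the scatter). The estimate for compound 3 in this assay is 15000 nM, with a range from 4000 nM to 50000 nM.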

Compound 3, half-maximal inhibitory concentration: 40000 nM
Compound 3: middle estimate off by 2.7-fold (0.43 log units), on the low side; the measured number falls inside the stated range.
By their numbers in this assay, from the lowest: compound 2; then compounds 3 and 1 (each within the scatter of the next).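

Replacing the 1-(4-fluorophenyl)pyrazole arm of compound 2 with 5-(methoxymethyl)-1H-pyrazol-3-yl gives a 29-fold higher number from compound 2 to compound 3 (1.46 log units; beyond the scatter) in this assay, so this new group does not keep the large gain seen in compound 2. The comparison with the first compound is more telling: a 1.3-fold lower number from compound 1 to compound 3 (0.10 log units; within the scatter) places two differently built pyrazole arms, one with an ethyl group and one with a methoxymethyl group and a hydrogen-bond donor, within the usual scatter of each other, and among these three compounds only compound 2, the one with a six-membered aromatic ring of carbon only, stands apart. Nothing measured here explains why the numbers fall this way.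

The three compounds leave open whether the gain in compound 2 comes from the benzene ring alone or needs its fluorine, a question that a plain phenyl or a 4-chlorophenyl on the aromatic nitrogen would address. They also leave open whether a benzyl group, with one extra carbon between the two rings, would keep that gain, and whether a methoxymethyl group would be tolerated on the pyrazole of compound 2.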